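The compounds below may be only part of what the source reports. "The series", "measured", "known", "first", "only" and "open" are said of these compounds alone.

Measured in a functional assay on HCT-116 cells (Homo sapiens) for inhibition, read by sulforhodamine B assay, with a stated time of 3 days; a lower number here means a stronger inhibitor of growth, a higher number a weaker inhibitor of growth:
- Compound 1 `Cc1ccc(COc2ccc(C(=O)/C=C/c3ccccc3)cc2)cc1`: > 50000 nM (a limit)
- Compound 2 `O=C(/C=C/c1ccccc1)c1ccc(OCc2ccccc2)cc1`: > 50000 nM (a limit)

Compound 2 stands at the limit of > 50000 nM in this assay, at which 2 of the 2 values shown sit, so its place is known only as a limit. Compound 3 `COc1cccc(/C=C/C(=O)c2ccc(OCc3ccccc3)cc2)c1` carries methoxy in place of hydrogen on an aromatic carbon. Going by the values given here, the only measured step, a step that the two limits leave unreadable from compound 1 to compound 2, also changes a small group on an aromatic carbon, but its size cannot be read. Among the compounds with values here, no sizeable step, in either direction, is therefore expected in this assay. The expected step is an at least 1.2-fold lower number from compound 2 to compound 3 (0.09 log units; that floor lies within the scatter). For compound 3 the estimate is 40000 nM, with an expected range of 10000 nM to 80000 nM.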

Compound 3, concentration for 50% growth inhibition: 35400 nM
The estimate for compound 3 lay 1.1-fold (0.05 log units) above the measured number; the measured number falls inside the stated range.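

In this assay, going by these compounds alone, compound 3 gives 35400 nM, the only value shown that is a number and not a limit, with methoxy on an aromatic carbon, meta to a large group. This change, phenyl to 3-methoxyphenyl, gives an at least 1.4-fold lower number from compound 2 to compound 3 (0.14 log units; that floor lies within the scatter) and shows no more than that floor. Compound 2 stands only at a limit: the limit of > 50000 nM in this assay, at which 2 of the 3 values shown sit.

The compounds shown leave open the true size of this step. They also leave open what a hydroxyl, an amine or a fluorine at this place would give.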